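Urea series: dose for half-maximal effect

A few compounds are considered here, and "the series" means these few. Any claim that something is new, unique, unknown or untested is made for them only; others in the source may bear on it.

Measured compounds:
Compound 1 `Cc1cc(C)c(NC(=O)N(Cc2ccc(-c3nnc(C)o3)cc2)C2CCCCCC2)c(C)c1`: > 0.32 mg/kg
Compound 2 `CSc1cc(C)nc(SC)c1NC(=O)N(Cc1ccccc1)Cc1ccc(-c2cc[nH]n2)cc1`: < 0.32 mg/kg
Compound 3 `O=C(Nc1c(F)cc(F)cc1F)N(Cc1ccc(-c2ccccn2)cc1)C1CCCCCC1`: > 1 mg/kg

In a functional assay on a cell-free system (plasma) with sterol O-acyltransferase, Soat (Rattus norvegicus) as the target (a lower number here means that less compound is needed, a higher number that more compound is needed for the effect), compound 1 gives > 0.32 mg/kg, which is a limit of the assay and not a number. Compound 1 therefore stands at the limit of > 0.32 mg/kg in this assay, at which 1 of the 3 values shown sits. Compound 2 gives < 0.32 mg/kg, likewise a limit. Compound 3 gives > 1 mg/kg, also a limit. For the measured compounds named here, none of the three values is a number, so no measured step between them can be stated, and compound 1 can only be placed at its own limit.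

Compound 4 `Cc1cc(C)c(NC(=O)N(Cc2ccc(-c3ccn(C)n3)cc2)C2CCCCCC2)c(C)c1` is the next member. It differs from compound 1 in one place: 1-methyl-1H-pyrazol-3-yl in place of 5-methyl-1,3,4-oxadiazol-2-yl on an aromatic carbon. Going by the values given here, with no measured step to lean on, the expected change from compound 1 to compound 4 in this assay is small, with no clear direction beyond the usual scatter. Compound 4 is accordingly estimated at 0.5 mg/kg, within a range of 0.1 mg/kg to 3 mg/kg, which corresponds to an expected step that the limit leaves unreadable from compound 1 to compound 4.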

Compound 4, dose for half-maximal effect: < 1 mg/kg
Compound 4 ended at the assay's limit; the forecaster's own chance of this, stated with the estimate: 55%; the middle value does not contradict the limit.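

In this assay, for the compounds shown here, the values of compound 1 and compound 4 are both limits and not numbers, so no step between the two can be read. The compounds shown leave open how large the change from 5-methyl-1,3,4-oxadiazol-2-yl to 1-methyl-1H-pyrazol-3-yl is, and in which direction it runs.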